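A few compounds are considered here, and "the series" means these few. Any claim that something is new, unique, unknown or untested is made for them only; others in the source may bear on it.

Of the compounds shown here, three sharing one core have been measured in a functional assay on the whole organism (strain Jcl:SD) for inhibition, with Rattus norvegicus as the target, with stated times of 3 min and 3 h, at a dose of 1 mg/kg by the intravenous route; a lower number here means less inhibition, a higher number more inhibition at the dose given (going by the name of the read-out). Compound 1 `CNCc1cc(-c2cccnc2F)n(S(=O)(=O)c2ccccc2)c1` gives 99% in this assay. Compound 2 `CNCc1cc(-c2cccnc2F)n(S(=O)(=O)c2cccc(OC)c2)c1`, which carries methoxy in place of hydrogen on an aromatic carbon, gives 92% in this assay, a change of a number 7 percentage points lower from compound 1 to compound 2 (within the scatter). Compound 3 `CNCc1cc(-c2cccnc2F)n(S(=O)(=O)c2ccoc2)c1`, with furan-3-yl on the sulfonyl sulfur, gives 82% in this assay. Compound 3 therefore holds the lowest of the three numbers: it lies a number 10 percentage points lower from compound 2 to compound 3 (within the scatter), which is within the scatter, and a number 17 percentage points lower from compound 1 to compound 3 (beyond the scatter), which is beyond it.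

Compound 4 `CNCc1cc(-c2cccnc2F)n(S(=O)(=O)c2ccco2)c1` is the unmeasured partner. It differs from compound 3 in one place: furan-2-yl in place of furan-3-yl on a sulfonyl sulfur. The two measured steps that bear on this position are those altering the group on the sulfonyl sulfur, namely a number 17 percentage points lower from compound 1 to compound 3 (beyond the scatter) and a number 10 percentage points lower from compound 2 to compound 3 (within the scatter). Both were modest at most, and the present change keeps the same atoms and only rearranges the ring attachment, a smaller change than either of those. For compound 4 the step is therefore expected to be a number 2 percentage points lower from compound 3 to compound 4 (within the scatter), meaning no movement beyond the scatter in this assay. Compound 4 is estimated to give 80% in this assay, within a range from 62% to 94%.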

Compound 4, a percentage reported as inhibition, in the whole organism at one dose (the size of the read-out at that dose, not a potency) in the Rattus norvegicus assay: 74%
The estimate for compound 4 lay 6 percentage points above the measured number; measured number inside the range.
By their numbers in the Rattus norvegicus assay, from the lowest: compounds 4, 3, 2 and 1 (each within the scatter of the next, the first and the last beyond it).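

In the Rattus norvegicus assay the shift of the ring attachment on the sulfonyl sulfur gives a number 8 percentage points lower from compound 3 to compound 4 (within the scatter) and so does not separate the two furans, yet the comparisons with the benzene-based sulfonyl groups sharpen: a number 18 percentage points lower from compound 2 to compound 4 (beyond the scatter) and a number 25 percentage points lower from compound 1 to compound 4 (beyond the scatter) both stand beyond the scatter, whereas compound 3 stayed within the scatter of compound 2. Furan-2-yl is thus the first group at this position to stand clear of both 3-methoxyphenyl and phenyl, though its margin over furan-3-yl is not itself resolved. In a physicochemical assay for lipophilicity, read by HPLC, at pH 7.4 (on this read-out higher numbers stand for higher lipophilicity and lower numbers for lower lipophilicity), compound 3 gives -1.31 and compound 4 gives -1.15, a pair described by a number 0.16 log units higher from compound 3 to compound 4 (within the scatter) and so not separated on this read-out either, and nothing at hand explains why the two furans differ in their standing against compound 2.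

The compounds shown leave open whether an alkyl chain such as propyl on the sulfonyl sulfur would fall further in the Rattus norvegicus assay or return towards the number of compound 1. They also leave open what a methyl group or an amine on the furan-2-yl ring would do.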